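Swapping 3,5-dimethylphenyl for 3-chlorophenyl on a sulfonamide nitrogen

A few compounds are considered here, and "the series" means these few. Any claim that something is new, unique, unknown or untested is made for them only; others in the source may bear on it.

- compound 1 `CCc1cccc(NS(=O)(=O)c2ccc(N3CCNC3=O)cc2)c1`: 200 nM
- compound 2 `O=C1NCCN1c1ccc(S(=O)(=O)Nc2cccc(Br)c2)cc1`: 99 nM
- compound 3 `Cc1cc(C)cc(NS(=O)(=O)c2ccc(N3CCNC3=O)cc2)c1`: 110 nM

These numbers come from a functional assay on L1210 cells (Mus musculus) for antiproliferative activity, read by sulforhodamine B assay, with a stated time of 48 h; a lower number here means a stronger inhibitor, a higher number a weaker inhibitor. The series spans a narrow range, and compound 3 cannot be separated from either of the other two: one gap is a 1.1-fold higher number from compound 2 to compound 3 (0.05 log units; within the scatter), the other 1.8-fold lower number from compound 1 to compound 3 (0.26 log units; within the scatter).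

The next compound, compound 4 `O=C1NCCN1c1ccc(S(=O)(=O)Nc2cccc(Cl)c2)cc1`, carries 3-chlorophenyl in place of 3,5-dimethylphenyl on a sulfonamide nitrogen. The closest guide is compound 2, which has 3-bromophenyl on that nitrogen and gives 99 nM. Changes to this group have moved the number little so far, and the largest is only modest: a 2.0-fold lower number from compound 1 to compound 2 (0.31 log units; beyond the scatter). No step beyond the scatter is therefore expected in this assay, in either direction. The expected change is a 1.1-fold higher number from compound 3 to compound 4 (0.04 log units; within the scatter). Compound 4 is estimated at 120 nM, with a likely range from 60 nM to 230 nM.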

Compound 4, half-maximal inhibitory concentration: 77 nM
Compound 4: middle estimate off by 1.6-fold (0.19 log units), on the high side, within the range that was stated.
By their numbers in this assay, from the lowest: compounds 4, 2, 3 and 1 (each within the scatter of the next, the first and the last beyond it).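

In this assay chloro in place of bromo gives a 1.3-fold lower number from compound 2 to compound 4 (0.11 log units; within the scatter) and 3-chlorophenyl in place of 3,5-dimethylphenyl gives a 1.4-fold lower number from compound 3 to compound 4 (0.15 log units; within the scatter) so on this sulfonamide nitrogen the new group cannot be told apart from either. Chloro in place of ethyl gives a 2.6-fold lower number from compound 1 to compound 4 (0.41 log units; beyond the scatter) and bromo in place of ethyl gives a 2.0-fold lower number from compound 1 to compound 2 (0.31 log units; beyond the scatter) so both halogen compounds now stand modestly apart from compound 1, while compound 3 goes against this and stays within the scatter of it. No outside evidence bears on why these groups differ so little.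

The compounds shown carry only ethyl, methyl, bromo and chloro on this aromatic ring, so how an amine, a carboxylic acid or a longer chain would behave there remains open. On these data alone, whether these small differences hold in other cell lines also remains open.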